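The source may hold more compounds than are shown below. What is called first, only, known or untested is meant among the compounds shown, and "the series" means these compounds.

In a functional assay on HL-60 cells (Homo sapiens) for antiproliferative activity, read by CCK-8 assay, with a stated time of 48 h (on this read-out lower numbers stand for stronger inhibition and higher numbers for weaker inhibition), compound 1 (`COc1ccc2sc(NC(=O)c3cc(=O)c4ccccc4o3)nc2c1`) gives 250 nM while compound 3 (`O=C(Nc1nc2cc(F)ccc2s1)c1cc(=O)c2ccccc2o1`) gives 310 nM and compound 2 (`O=C(Nc1nc(-c2ccc(F)cc2)cs1)c1cc(=O)c2ccccc2o1`) gives 420 nM as its result. Compound 2 therefore lies within the usual scatter of both other compounds, and no order among the three can be claimed.

Compound 4 (`O=C(Nc1nc(-c2ccc(OC(F)(F)F)cc2)cs1)c1cc(=O)c2ccccc2o1`) differs from compound 2 in one place, with trifluoromethoxy in place of fluoro on an aromatic carbon. Among the compounds with values here, only one measured step exchanges one group on an aromatic carbon for another, namely a 1.2-fold higher number from compound 1 to compound 3 (0.09 log units; within the scatter) for fluoro in place of methoxy. That step stays within the scatter, but it sits on a different core and involves a different pair of groups, so it offers only weak guidance. Within the data shown here, no measured compound carries trifluoromethoxy. No step beyond the scatter is expected in this assay in either direction. The estimate amounts to an expected step of a 1.1-fold lower number from compound 2 to compound 4 (0.02 log units; within the scatter) and nothing more. For compound 4 the estimated value is 400 nM with an expected range from 170 nM to 950 nM in this measurement.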

Compound 4, half-maximal inhibitory concentration: 590 nM
Estimate against measurement, compound 4: 1.5-fold (0.17 log units) below; measured number inside the range.
By their numbers in this assay, from the lowest: compounds 1, 3, 2 and 4 (each within the scatter of the next, the first and the last beyond it).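

In this assay, putting trifluoromethoxy, with five heavy atoms and one hydrogen-bond acceptor, in place of fluoro, with one heavy atom and no acceptor, gives a 1.4-fold higher number from compound 2 to compound 4 (0.15 log units; within the scatter). Within the data shown here, this is the first measured exchange at this position, on an aromatic carbon para to a large group, and the two numbers cannot be told apart, so a much larger group is accommodated here without a clear loss or gain in this read-out. No measurement is available to explain this result.

Going by these compounds, it remains open whether a group of a different kind here, such as an amine or a carboxylic acid, would also stay within the scatter. On these data alone, it is also open whether trifluoromethoxy would give a similar step on the core of compound 1.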